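Dichloro purine to monochloro: loss of the second chloro

A few compounds are considered here, and "the series" means these few. Any claim that something is new, unique, unknown or untested is made for them only; others in the source may bear on it.

Measured so far:
compound 1 `ClCc1ccc(Cn2cnc3c(Cl)ncnc32)cc1` with 7940 nM
compound 2 `ClCc1ccccc1Cn1cnc2c(Cl)nc(Cl)nc21` with 1230 nM

Going by the values given here, in a functional assay on SK-MEL-28 cells (Homo sapiens) for cytotoxicity, read by sulforhodamine B assay, with a stated time of 48 h (a higher number here means a weaker inhibitor of growth, a lower number a stronger inhibitor of growth), compound 2 gives the lowest of the two numbers so far. The nearest number is that of compound 1, whose value in this assay is higher by a gap beyond the usual scatter.

Compound 3 `ClCc1ccccc1Cn1cnc2c(Cl)ncnc21` has not yet been run in this assay. It differs from compound 2 in one place: hydrogen in place of chloro on an aromatic carbon, in short hydrogen in place of chloro on an aromatic carbon. Among the compounds with values here, no step between two measured compounds isolates this change, so its size is not known from the series itself. Within the data shown here, the only guide is that compound 1, which carries only one chloro on the core, gives 7940 nM, a weaker growth inhibition than compound 2 shows with 1230 nM.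

On that basis the step from compound 2 to compound 3 is expected to go toward a higher number, by a 3.3-fold higher number from compound 2 to compound 3 (0.51 log units; beyond the scatter). For compound 3 the estimate in this assay is 4000 nM, with a range from 1200 nM to 13000 nM.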

Compound 3, concentration for 50% growth inhibition: 2290 nM
Beside the measured number, compound 3's estimate is 1.7-fold (0.24 log units) above it; low and high end bracket the measured number.
By their numbers in this assay, from the lowest: compounds 2 and 3 (each within the scatter of the next); then compound 1.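

In this assay, the chloro between two ring nitrogen atoms now has a step of its own: hydrogen in place of chloro on this aromatic carbon gives a 1.9-fold higher number from compound 2 to compound 3 (0.27 log units; within the scatter) and so does not separate compound 3 from compound 2. This chloro is therefore not needed to keep the number in this range, and the second chloro on the core of compound 2 can be removed without a change beyond the scatter in this read-out. No measurement on hand bears on why this position tolerates the change.

Only chloro and hydrogen stand at this position in the compounds shown, so it remains open whether an amine, a methoxy group or a longer chain there would move the number beyond the scatter in either direction. Also open, going by these compounds, is whether the remaining chloro on the core, which is common to compound 2 and compound 3, can be replaced by hydrogen or an amine with as little consequence.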